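The source may hold more compounds than are shown below. What is called first, only, known or untested is meant among the compounds shown, and "the series" means these compounds.

Measured in an ADME assay on MDCKII-LE cells (Canis lupus familiaris) for permeability, read by transwell migration, in the apical to basolateral direction; a higher number here means that the compound crosses the layer faster, a lower number that the compound crosses the layer more slowly:
compound 1 `CC1(C)CO[C@@H]1CN([C@H](CCC(F)(F)F)C(N)=O)S(=O)(=O)c1ccc(Cl)cc1`: 22.3 10^-6 cm/s
compound 2 `NC(=O)[C@@H](CCC(F)(F)F)N(CC1CCCC1)S(=O)(=O)c1ccc(Cl)cc1`: 6.01 10^-6 cm/s
compound 3 `NC(=O)[C@@H](CCC(F)(F)F)N(C[C@H]1CCCOC1)S(=O)(=O)c1ccc(Cl)cc1`: 18.2 10^-6 cm/s

Compound 3 cannot be told apart from compound 1, since a 1.2-fold lower number from compound 1 to compound 3 (0.09 log units; within the scatter) stays within the scatter. It clearly separates from compound 2, with a 3.0-fold higher number from compound 2 to compound 3 (0.48 log units; beyond the scatter). The next analogue, compound 4 `NC(=O)[C@@H](CCC(F)(F)F)N(CC1CCOCC1)S(=O)(=O)c1ccc(Cl)cc1`, keeps the shared core and makes a single change: oxan-4-yl in place of oxan-3-yl on a saturated chain carbon bound to a sulfonamide nitrogen. In words, oxan-4-yl stands in place of oxan-3-yl on a saturated chain carbon bound to a sulfonamide nitrogen, so the two compounds have the same atoms, joined differently.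

Among the compounds with values here, no measured step makes this exact change, so the evidence comes from other swaps at the same place. Within the data shown here, both steps beyond the scatter involve cyclopentyl, the only group of the three without a ring oxygen, and a 3.7-fold lower number from compound 1 to compound 2 (0.57 log units; beyond the scatter) is modest. Compound 4 keeps a ring oxygen, so no step beyond the scatter is expected in this assay, because a 1.2-fold lower number from compound 1 to compound 3 (0.09 log units; within the scatter) showed that exchanging one oxygen-bearing ring for another made no resolved difference. Among the measured compounds shown here, this rests on only three compounds. The expected step is small, a 1.2-fold lower number from compound 3 to compound 4 (0.08 log units; within the scatter). Compound 4 is estimated at 15 10^-6 cm/s, with an expected range of 7.5 10^-6 cm/s to 28 10^-6 cm/s.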

Compound 4, apparent permeability: 26.3 10^-6 cm/s
The estimate for compound 4 lay 1.8-fold (0.24 log units) below the measured number, and the stated range covers the measured number.
By their numbers in this assay, from the lowest: compound 2; then compounds 3, 1 and 4 (each within the scatter of the next).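

Exchanging oxan-3-yl for oxan-4-yl on a saturated chain carbon bound to a sulfonamide nitrogen, which keeps the same atoms joined differently, made no resolved difference in this assay, with a 1.4-fold higher number from compound 3 to compound 4 (0.16 log units; within the scatter). A third oxygen-bearing ring now falls in the same range, as a 1.2-fold higher number from compound 1 to compound 4 (0.07 log units; within the scatter) also stays within the scatter, while a 4.4-fold higher number from compound 2 to compound 4 (0.64 log units; beyond the scatter) lies beyond it, so that among these four only cyclopentyl, the one group without a ring oxygen, stands apart. Nothing in the available data explains why cyclopentyl separates from the three oxygen-bearing rings.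

The compounds shown leave open whether a ring oxygen is specifically required, or whether a piperidin-4-yl ring with its ring nitrogen, or a thian-4-yl ring with its ring sulfur, would group with compounds 1, 3 and 4 or with compound 2. They also do not show whether an open-chain ether such as 2-methoxyethyl, or a carboxylic acid, at this place would stay in the range of the oxygen-bearing rings.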